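The source may report more compounds than this note shows. Statements on the series, on what has been measured and on what is new or still open speak of the compounds shown alone.

Working notes on the bis(trifluoromethyl)benzenesulfonamide series, read in a functional assay on MCF7 cells (Homo sapiens) for inhibition, read by MTT assay, with a stated time of 72 h; on this read-out higher numbers stand for weaker inhibition of growth and lower numbers for stronger inhibition of growth. Of the compounds shown here, three carry numbers so far. Compound 1 `CC(C)(C)c1ccc(CNCCNS(=O)(=O)c2cc(C(F)(F)F)cc(C(F)(F)F)c2)cc1` gives 13000 nM. Compound 2 `O=S(=O)(NCCCCNCc1ccc(Br)cc1)c1cc(C(F)(F)F)cc(C(F)(F)F)c1` gives 1500 nM. Compound 3 `O=S(=O)(NCCCNCC1COc2ccccc2O1)c1cc(C(F)(F)F)cc(C(F)(F)F)c1` gives 2500 nM. Among these, compound 2 stands at the lowest of the three numbers; its gap to compound 3 is within the scatter, while its gap to compound 1 lies beyond it. Going by the values given here, no pair of measured compounds differs in a single place, so no step between measured compounds can be read directly.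

The next compound, compound 4 `CN(CCCNS(=O)(=O)c1cc(C(F)(F)F)cc(C(F)(F)F)c1)Cc1ccccc1`, is compared with compound 2. The change is benzyl(methyl)amino in place of ((4-bromobenzyl)amino)methyl on a saturated chain carbon, three bonds along the chain from a sulfonamide nitrogen. The bromine is gone, the chain is shorter by the count given, and the amine carries a methyl rather than a hydrogen. Nothing measured here isolates any one of these changes, so the step is expected to be modest, most likely a rise in the number, and possibly none beyond the scatter. The step from compound 2 to compound 4 is therefore estimated at a 2.7-fold higher number from compound 2 to compound 4 (0.43 log units; beyond the scatter). For compound 4 the expected value in this assay is 4000 nM, with a range from 1500 nM to 12000 nM.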

Compound 4, concentration for 50% growth inhibition: 16000 nM
Compound 4: middle estimate off by 4.0-fold (0.60 log units), on the low side, outside the stated range (above it).
By their numbers in this assay, from the lowest: compounds 2 and 3 (each within the scatter of the next); then compounds 1 and 4 (each within the scatter of the next).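

In this assay the swap of ((4-bromobenzyl)amino)methyl for benzyl(methyl)amino on a saturated chain carbon, three bonds along the chain from a sulfonamide nitrogen, gives an 11-fold higher number from compound 2 to compound 4 (1.03 log units; beyond the scatter) and is a large step. Going by these compounds alone, this is the first single-place step, so it shows that the number responds strongly to a change at this position. The entering group has 0 hydrogen-bond donors against 1 in the leaving group and has no bromine, and no measurement on the compounds shown accounts for the step.

Which part of the change carries the step, the bromine, the methyl on the amine or the chain, cannot be read from these compounds. Also open, going by these compounds, is how a benzylamino group without the methyl, or benzyl(methyl)amino on a longer chain, would read.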